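This account rests on a few compounds, and the source may have more. Where it says the series, first, only, none or still open, it means among the compounds named here.

Measured compounds in a functional assay on CHO-K1 cells for agonist activity at Orexin/Hypocretin receptor type 1 (Homo sapiens), read by calcium flux; on this read-out lower numbers stand for an effect already at smaller amounts and higher numbers for an effect only at larger amounts of compound: compound 1 `COc1ccccc1C(=O)NCCNc1cccc(NS(=O)(=O)c2cc(-c3cccc(C(=O)N(C)C)c3)ccc2OC)c1` gives 5230 nM; compound 2 `COc1ccc(-c2cccc(C(=O)N(C)C)c2)cc1S(=O)(=O)Nc1cccc(NCCNC(=O)c2ccccc2Cl)c1` gives 6130 nM.

Compound 2 has the higher of the two numbers, but its distance to compound 1 is small: a 1.2-fold higher number from compound 1 to compound 2 (0.07 log units; within the scatter). Compound 3 `COc1ccc(-c2cccc(C(=O)N(C)C)c2)cc1S(=O)(=O)Nc1cccc(NCCNC(=O)c2cccc(Cl)c2)c1` carries the change (3-chlorophenyl in place of 2-chlorophenyl on a carbonyl carbon). For the measured compounds named here, no measured step moves a chloro from one ring carbon to another; the only step seen, from compound 1 to compound 2, exchanged a methoxy for a chloro and stayed within the scatter. On that thin basis no step beyond the scatter is expected for compound 3, so a 1.0-fold lower number from compound 2 to compound 3 (0.01 log units; within the scatter) is the estimated step, and compound 3 is expected to give about 6000 nM (range 2000 nM to 18000 nM).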

Compound 3, half-maximal effective concentration: 5720 nM
For compound 3 the middle estimate is 1.0-fold (0.02 log units) above the measured one, and the stated range covers the measured number.
By their numbers in this assay, from the lowest: compounds 1, 3 and 2 (each within the scatter of the next).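

In this assay, 3-chlorophenyl in place of 2-chlorophenyl on the carbonyl carbon gives a 1.1-fold lower number from compound 2 to compound 3 (0.03 log units; within the scatter) and thus shows, for this one pair, that shifting the chloro around this ring leaves the number within the scatter. 3-chlorophenyl in place of 2-methoxyphenyl gives a 1.1-fold higher number from compound 1 to compound 3 (0.04 log units; within the scatter) and so all three rings tested here read alike. Nothing at hand offers a reason for this. The compounds shown leave open whether 4-chlorophenyl, or an amine or a carboxylic acid in place of the ring, would read differently.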